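The source may hold more compounds than are shown below. What is called first, only, known or untested is meant among the compounds shown, and "the series" means these compounds.

Measured so far in an ADME assay on MT4 cells (Homo sapiens) for cytotoxicity, read by MTT assay, with a stated time of 3 days (on this read-out lower numbers stand for higher toxicity in this test and higher numbers for lower toxicity in this test), are two compounds:
Compound 1 `CC(C)OC(=O)COC(=O)c1ccc([N+](=O)[O-])o1` gives > 100000 nM
Compound 2 `CC(C)(C)N(CCC(=O)c1ccccc1)C(=O)COC(=O)c1ccc([N+](=O)[O-])o1` gives "not active" (no number reported)

Compound 1 gives > 100000 nM as a limit of the assay and not as a number. Compound 1 thus stands at the limit of > 100000 nM in this assay, at which 1 of the 2 values shown sits, and has no exact figure. Compound 2 carries the entry "not active" (no number reported) and offers no number for comparison.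

Compound 3 `CC(=O)COC(=O)c1ccc([N+](=O)[O-])o1` keeps the core of compound 1 and has methyl in place of isopropoxy on a carbonyl carbon, a change counted as methyl in place of isopropoxy on a carbonyl carbon in full. Within the data shown here, no pair of measured compounds shows the size of such a change. In this assay the expected change is a number no higher from compound 1 to compound 3 (the limit leaves the size open) and no larger than the usual scatter, with neither direction favoured. The assay may well report only a limit again. For compound 3 the estimated value is 100000 nM with an expected range from 35000 nM to 200000 nM in this measurement.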

Compound 3, half-maximal cytotoxic concentration: > 100000 nM
Compound 3 was reported as a limit; the forecaster's own chance of this, stated with the estimate: 70%; the middle value sits exactly at the limit.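

Compound 1 and compound 3 both end at a limit of the assay and not at an exact number, so no step can be read between them: the limit of > 100000 nM in this assay, at which 2 of the 3 values shown sit.

The compounds shown leave open whether methyl in place of isopropoxy on a carbonyl carbon alters cytotoxicity at all.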